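Swapping the Aryl Group of Compound 3

The compounds below may be only part of what the source reports. "The series", "measured", "known", "first", "only" and "open" are said of these compounds alone.

Of the compounds shown here, three sharing one core have been measured in an assay on isolated protein for inhibition of Fatty-acid amide hydrolase 1 (Homo sapiens); on this read-out lower numbers stand for stronger inhibition and higher numbers for weaker inhibition. Compound 1 `CC(C)S(=O)(=O)N1CCC(CCCC(=O)c2ncco2)CC1` gives 140 nM. Compound 2 `Cc1cccc(CN2CCC(CCCC(=O)c3ncco3)CC2)c1` gives 90 nM, and compound 3 `O=C(CCCC1CCN(Cc2ccccc2Cl)CC1)c1ncco1` gives 260 nM. Compound 3 carries the highest number of the three, although its gap to compound 1 stays within the scatter; only the move a 2.9-fold higher number from compound 2 to compound 3 (0.46 log units; beyond the scatter) lies beyond it. Compound 4 `O=C(CCCC1CCN(Cc2ccc(Br)cc2)CC1)c1ncco1` has not yet been measured. It differs from compound 3 in one place: 4-bromophenyl in place of 2-chlorophenyl on a saturated chain carbon bound to an amine nitrogen in a ring. The step that bears most directly on this change is a 2.9-fold higher number from compound 2 to compound 3 (0.46 log units; beyond the scatter), the only one that alters the aryl group on that carbon; the two others, a 1.6-fold lower number from compound 1 to compound 2 (0.19 log units; within the scatter) and a 1.9-fold higher number from compound 1 to compound 3 (0.27 log units; within the scatter), exchange the whole group on the ring nitrogen and stayed within the scatter. Among the measured compounds shown here, no measured compound yet shows 4-bromophenyl in this position, so the direction of the coming step rests on a single measured move. The expectation is a modest move downward, a 1.7-fold lower number from compound 3 to compound 4 (0.24 log units; within the scatter), held with considerable uncertainty. Compound 4 is estimated at 150 nM, within a range from 50 nM to 500 nM.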

Compound 4, half-maximal inhibitory concentration: 45 nM
Compound 4: the middle estimate sits 3.3-fold (0.52 log units) above what was measured; the measured number lies below the stated range.
By their numbers in this assay, from the lowest: compounds 4, 2, 1 and 3 (each within the scatter of the next, the first and the last beyond it).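

In this assay the 2-chlorophenyl of compound 3 now stands apart from both other aryl groups on that carbon: the new change gives a 5.8-fold lower number from compound 3 to compound 4 (0.76 log units; beyond the scatter) and so runs opposite to the earlier 2.9-fold higher number from compound 2 to compound 3 (0.46 log units; beyond the scatter) with both steps beyond the scatter. The other aryl pair gives a 2.0-fold lower number from compound 2 to compound 4 (0.30 log units; within the scatter) and thus leaves 4-bromophenyl and 3-methylphenyl indistinguishable here, so among these three aryl groups only 2-chlorophenyl goes against a shared level. Among the compounds shown here, the exchange of the whole group on the ring nitrogen, which stayed within the scatter for both earlier benzyl compounds, now gives a 3.1-fold lower number from compound 1 to compound 4 (0.49 log units; beyond the scatter) and is the first such exchange to pass beyond it, although it does so for 4-bromobenzyl alone.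

The compounds shown leave open whether the halogen or its place on the ring separates compound 3 from compound 4, since 4-chlorophenyl, 2-bromophenyl and plain phenyl do not appear among them. No evidence is available on why this aryl change shifts the number so strongly.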